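Swapping the benzyl ring substituent on a shared oxadiazole-thioether scaffold

A few compounds are considered here, and "the series" means these few. Any claim that something is new, unique, unknown or untested is made for them only; others in the source may bear on it.

Measured so far:
compound 1 `COc1cc(-c2nnc(SCc3ccc(F)cc3F)o2)ccc1O` – 9690 nM
compound 2 `COc1cc(-c2nnc(SCc3ccccc3C)o2)ccc1O` – 8420 nM

Both compounds were tested in a functional assay on cells (T-cell, Mus musculus, strain BALB/c) for inhibition, read by MTT assay, with stated times of 24 h and 72 h; a higher number here means a weaker inhibitor, a lower number a stronger inhibitor. Compound 2 shows the lowest of the two numbers, but its nearest neighbour is compound 1, and the step of a 1.2-fold lower number from compound 1 to compound 2 (0.06 log units; within the scatter) lies within the scatter, so the two cannot be told apart. That step is the only one measured, and it concerns the same place on the shared core: 2-methylphenyl in place of 2,4-difluorophenyl on a saturated chain carbon bound to a sulfur.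

Compound 3 `COc1cccc(CSc2nnc(-c3ccc(O)c(OC)c3)o2)c1` is not yet measured. It differs from compound 2 as follows: 3-methoxyphenyl in place of 2-methylphenyl on a saturated chain carbon bound to a sulfur. For the measured compounds named here, no measured step covers a methoxy-bearing ring at this place, so the expectation rests on the sole comparison available, which showed no shift beyond the scatter when the ring at this place was varied.

For compound 3 the estimated step is therefore a 1.0-fold higher number from compound 2 to compound 3 (0.00 log units; within the scatter), that is, no change beyond the scatter is expected. Compound 3 is estimated to give 8500 nM, with a range from 4200 nM to 17000 nM.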

Compound 3, half-maximal inhibitory concentration: 7410 nM
Beside the measured number, compound 3's estimate is 1.1-fold (0.06 log units) above it; low and high end bracket the measured number.
By their numbers in this assay, from the lowest: compounds 3, 2 and 1 (each within the scatter of the next).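

Compared with 2-methylphenyl, the 3-methoxyphenyl ring brings an oxygen and a hydrogen-bond acceptor to the saturated chain carbon bound to a sulfur, and in this assay the swap gives a 1.1-fold lower number from compound 2 to compound 3 (0.06 log units; within the scatter) as its step. Measured against the 2,4-difluorophenyl ring, the same ring gives a 1.3-fold lower number from compound 1 to compound 3 (0.12 log units; within the scatter) as its step, so all three rings at this place now stand within the scatter of one another, and a ring with an oxygen-bearing group cannot be told apart from the other two. No measurement is available to explain this result.

Still open, going by these compounds, is whether any group at this place can move the number beyond the scatter. A ring carrying an amine or a carboxylic acid, or a longer chain at this place, would test that.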